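Replacing the Ester of Compound 3 with a Hydroxyethyl Ether

A few compounds are considered here, and "the series" means these few. Any claim that something is new, unique, unknown or untested is made for them only; others in the source may bear on it.

Compound 1 `CC(C)=CC[C@@H](OC(=O)C1CCOC1)C1=CC(=O)c2c(O)ccc(O)c2C1=O`, compound 2 `CC(C)=CC[C@@H](OC(=O)C1CCCO1)C1=CC(=O)c2c(O)ccc(O)c2C1=O` and compound 3 `CC(C)=CC[C@@H](OC(=O)C1CCCCO1)C1=CC(=O)c2c(O)ccc(O)c2C1=O` share one core and differ only in the ring attached to the carbonyl of the ester. In a functional assay on DU-145 cells (Homo sapiens) for cytotoxicity, read by MTT assay (on this read-out higher numbers stand for weaker inhibition and lower numbers for stronger inhibition), compound 1 gives 47500 nM, compound 2 gives 10500 nM and compound 3 gives 24700 nM, which places compound 3 second highest of the three: a 2.4-fold higher number from compound 2 to compound 3 (0.37 log units; beyond the scatter), while a 1.9-fold lower number from compound 1 to compound 3 (0.28 log units; within the scatter). Compound 4 `CC(C)=CC[C@@H](OCCO)C1=CC(=O)c2c(O)ccc(O)c2C1=O` carries 2-hydroxyethyl in place of (oxan-2-yl)carbonyl on an oxygen on a saturated carbon. Going by the values given here, none of the measured steps alters this part of the molecule, so none bears directly on the change; the whole set spans only a 4.5-fold lower number from compound 1 to compound 2 (0.66 log units; beyond the scatter). With no closer guide, the step of a 1.1-fold lower number from compound 3 to compound 4 (0.05 log units; within the scatter) is expected to stay modest, in either direction. Compound 4 is therefore estimated at 22000 nM, within 5000 nM to 90000 nM in this assay.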

Compound 4, half-maximal inhibitory concentration: 9900 nM
Compound 4: the middle estimate sits 2.2-fold (0.35 log units) above what was measured; the measured number falls inside the stated range.
By their numbers in this assay, from the lowest: compounds 4 and 2 (each within the scatter of the next); then compounds 3 and 1 (each within the scatter of the next).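

Replacing the ester with 2-hydroxyethyl removes the ring and the carbonyl, yet the number does not rise: the data show a 2.5-fold lower number from compound 3 to compound 4 (0.40 log units; beyond the scatter) and a 4.8-fold lower number from compound 1 to compound 4 (0.68 log units; beyond the scatter) on this change. Against the ester with the lowest number, the data show a 1.1-fold lower number from compound 2 to compound 4 (0.03 log units; within the scatter) so, among these compounds, the oxygen on a saturated carbon needs neither ring nor carbonyl to hold this level of cytotoxicity. Nothing measured here explains the result.

Going by these compounds, whether the hydroxyl of 2-hydroxyethyl matters stays open, since a plain ethyl or methoxyethyl group would test it. A longer chain or a terminal amine at this oxygen also remains an open question.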